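Swapping the amide substituent again on a shared core

A few compounds are considered here, and "the series" means these few. Any claim that something is new, unique, unknown or untested is made for them only; others in the source may bear on it.

Compound 1 `CCOc1nc2cccc(C(=O)Nc3ccncc3)c2n1Cc1ccc(-c2ccccc2-c2nnn[nH]2)cc1` and compound 2 `CCOc1nc2cccc(C(=O)NOCc3ccccc3)c2n1Cc1ccc(-c2ccccc2-c2nnn[nH]2)cc1` share one core and differ only at the amide nitrogen. In an assay on isolated protein for inhibition of NEDD8-activating enzyme E1 regulatory subunit (Homo sapiens), read by Western blot, with stated times of 10 min and 30 min, tested at 25 uM (on this read-out lower numbers stand for less inhibition and higher numbers for more inhibition at the one concentration tested (going by the name of the read-out)), compound 1 gives 39.8%, and compound 2 gives 39.8%; the step of no change at the digits printed from compound 1 to compound 2 (within the scatter) shows that exchange did nothing beyond the scatter. Compound 3 `CCOc1nc2cccc(C(=O)NCCCCc3ccccc3)c2n1Cc1ccc(-c2ccccc2-c2nnn[nH]2)cc1` carries the next change, (4-phenylbutyl in place of benzyloxy on an amide-type nitrogen). Among the measured compounds shown here, with only one relevant step, and that one flat, the expectation is a step of a number 0.2 percentage points higher from compound 2 to compound 3 (within the scatter) of no real size in either direction. Compound 3 is therefore estimated at 40%, with a range from 25% to 55%.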

Compound 3, a percentage reported as inhibition, at one concentration (the size of the read-out at that concentration, not a potency): 64.6%
Beside the measured number, compound 3's estimate is 24.6 percentage points below it, outside the stated range (above it).
By their numbers in this assay, from the lowest: compounds 1 and 2 (each within the scatter of the next); then compound 3.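

In this assay, the amide nitrogen proves able to move the read-out after all: 4-phenylbutyl in place of benzyloxy gives a number 24.8 percentage points higher from compound 2 to compound 3 (beyond the scatter), and 4-phenylbutyl in place of pyridin-4-yl gives a number 24.8 percentage points higher from compound 1 to compound 3 (beyond the scatter). The flat step between compound 1 and compound 2 therefore did not mean that every substituent here performs alike, and compound 3 stands highest of the three. No measurement shown here accounts for the rise.

Still open, from the compounds shown here alone, is how the number would respond to a longer chain, such as 6-phenylhexyl, or a shorter one, such as 2-phenylethyl. A butyl chain ending in an amine or a carboxylic acid instead of phenyl is equally untested among these compounds.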